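This account rests on a few compounds, and the source may have more. Where it says the series, first, only, none or still open, it means among the compounds named here.

Three compounds share one core and differ only in the aryl group on the five-membered ring that holds two nitrogens and one oxygen. Compound 1 `CS(=O)(=O)c1ccc(-c2cnc3[nH]cc(-c4nnc(-c5ccncc5)o4)c(=O)c3c2)cc1` carries a pyridin-4-yl group there; in a functional assay on HepG2 cells (Homo sapiens) for inhibition, read by MTT assay, with a stated time of 24 h, tested at 10 uM (on this read-out lower numbers stand for less inhibition of growth and higher numbers for more inhibition of growth at the one concentration tested), compound 1 gives 6.65%. Compound 2 `CS(=O)(=O)c1ccc(-c2cnc3[nH]cc(-c4nnc(-c5ccccc5)o4)c(=O)c3c2)cc1` carries a phenyl group, and in this assay compound 2 gives 6.98%. Compound 3 `CS(=O)(=O)c1ccc(-c2cnc3[nH]cc(-c4nnc(-c5ccc(Cl)cc5)o4)c(=O)c3c2)cc1` carries a 4-chlorophenyl group, and in this assay compound 3 gives 11.6%, the highest of the three numbers shown, though its steps to the others stay within the scatter: a number 5 percentage points higher from compound 1 to compound 3 (within the scatter) and a number 4.6 percentage points higher from compound 2 to compound 3 (within the scatter).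

Compound 4 `Cc1cccc(-c2nnc(-c3c[nH]c4ncc(-c5ccc(S(C)(=O)=O)cc5)cc4c3=O)o2)c1` differs from compound 3 by 3-methylphenyl in place of 4-chlorophenyl on an aromatic carbon. Within the data shown here, the steps that bear on this change are a number 4.6 percentage points higher from compound 2 to compound 3 (within the scatter), which swaps a substituent on the same phenyl ring, and a number 0.3 percentage points higher from compound 1 to compound 2 (within the scatter), which exchanges the whole aryl group. Neither exceeded the scatter, so no step beyond the scatter is expected: a number 3.6 percentage points lower from compound 3 to compound 4 (within the scatter). Compound 4 is therefore estimated at 8%, with a range from 0% to 20%.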

Compound 4, percent growth inhibition at one concentration: 13.3%
The estimate for compound 4 lay 5.3 percentage points below the measured number; low and high end bracket the measured number.
By their numbers in this assay, from the lowest: compounds 1, 2, 3 and 4 (each within the scatter of the next).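

In this assay, exchanging 4-chlorophenyl for 3-methylphenyl on this aromatic carbon of the five-membered ring gives a number 1.7 percentage points higher from compound 3 to compound 4 (within the scatter) and so adds a carbon-only substituent to the chloro group already seen on the phenyl ring, with no step beyond the scatter. Adding that methyl to the plain phenyl group gives a number 6.3 percentage points higher from compound 2 to compound 4 (within the scatter) and replacing pyridin-4-yl with 3-methylphenyl gives a number 6.7 percentage points higher from compound 1 to compound 4 (within the scatter) so that all the aryl exchanges shown here at this position remain within the scatter. No measurement bears on why these four aryl groups give such close numbers.

What the compounds shown leave open is whether any group at this position can move the number beyond the scatter. Going by these compounds, what an amine, a carboxylic acid or a longer chain would give in place of the aryl group also stays open.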